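The source may hold more compounds than are shown below. What is called first, only, known or untested is meant among the compounds shown, and "the series" means these compounds.

Of the compounds shown here, two of a shared core have been measured in a functional assay on CHO-K1 cells for antagonist activity at transient receptor potential cation channel subfamily V member 1 (Homo sapiens), read by FLIPR; a higher number here means a weaker inhibitor, a lower number a stronger inhibitor. Compound 1 `CC(C(=O)NCc1ccc(C(F)(F)F)nc1N(C)c1ccccc1)c1ccc(NS(C)(=O)=O)c(F)c1` gives 57.4 nM. Compound 2 `CC(C(=O)NCc1ccc(C(F)(F)F)nc1N1CCCC1)c1ccc(NS(C)(=O)=O)c(F)c1` gives 211 nM, the higher of the two numbers and so the weaker inhibitor of the pair. For the measured compounds named here, the single step between them, a 3.7-fold higher number from compound 1 to compound 2 (0.57 log units; beyond the scatter), is the only measured change at this position and therefore the only guide for what follows.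

Compound 3 `CC(C(=O)NCc1ccc(C(F)(F)F)nc1N1CC=CCC1)c1ccc(NS(C)(=O)=O)c(F)c1` differs from compound 2 at the same aromatic carbon: a group of 6 heavy atoms (5 carbon, 1 nitrogen; one six-membered non-aromatic ring with 1 hetero atom) in place of a group of 5 heavy atoms (4 carbon, 1 nitrogen; one five-membered non-aromatic ring with 1 hetero atom), on an aromatic carbon. Going by the values given here, the one measured step shows that this position is sensitive to what the attached group looks like, since swapping a methyl(phenyl)amino group for a small saturated ring cost potency. Expanding that ring by one carbon and adding a double bond is a smaller change than the measured one, so the expected step is estimated to stay near or within the scatter, a 1.3-fold lower number from compound 2 to compound 3 (0.12 log units; within the scatter). Compound 3 is therefore expected to give about 160 nM, with a likely range from 55 nM to 450 nM.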

Compound 3, half-maximal inhibitory concentration: 12.1 nM
Compound 3: middle estimate off by 13-fold (1.12 log units), on the high side; measured number outside the range, below it.
By their numbers in this assay, from the lowest: compound 3; then compound 1; then compound 2.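

In this assay, this position proves far more responsive to the form of a small ring than the first pair suggested: the six-membered non-aromatic ring with its double bond gives a 17-fold lower number from compound 2 to compound 3 (1.24 log units; beyond the scatter) in place of pyrrolidin-1-yl. The same ring also gives a 4.7-fold lower number from compound 1 to compound 3 (0.68 log units; beyond the scatter) in place of methyl(phenyl)amino, so among these three compounds the group with the phenyl ring is not the one with the lowest number, and replacing it with a smaller ring can either lower or raise the number, depending on the ring. The data offer no measured explanation for why this ring differs so sharply from pyrrolidin-1-yl.

This change altered two things at once, the ring size and the double bond, so the compounds shown cannot say how much each one contributes; piperidin-1-yl, the same six-membered ring without the double bond, would separate the two. Also open, on these data alone, is how the position responds to a ring carrying oxygen, such as morpholin-4-yl, or to a larger ring, such as azepan-1-yl.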